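This account rests on a few compounds, and the source may have more. Where it says the series, first, only, none or still open, it means among the compounds named here.

Series notes. The shared core of compound 1 `Cn1c(COc2cccc(C(=O)O)c2)nc2ccc(Oc3cccc(Cl)n3)cc21` carries a pyridyl ether, and three variants have numbers in an ADME assay for permeability, using PAMPA, with a stated time of 4 h; on this read-out higher numbers stand for higher permeability and lower numbers for lower permeability. Compound 1 gives 7.6 10^-6 cm/s. Compound 2 `Cc1cccnc1Oc1ccc2nc(COc3cccc(C(=O)O)c3)n(C)c2c1` gives 6 10^-6 cm/s in this assay, and compound 3 `Cn1c(COc2cccc(C(=O)O)c2)nc2ccc(Oc3ccc(F)cn3)cc21` gives 4.7 10^-6 cm/s. Among the three, compound 3 sits at the low end, but the spread is small: the step is a 1.6-fold lower number from compound 1 to compound 3 (0.21 log units; within the scatter), and a 1.3-fold lower number from compound 2 to compound 3 (0.11 log units; within the scatter), so none of the three separates from the others in this assay.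

Compound 4 `Cc1cc(F)cnc1Oc1ccc2nc(COc3cccc(C(=O)O)c3)n(C)c2c1` is not yet measured. Its change from compound 3 is methyl in place of hydrogen on an aromatic carbon. Among the measured compounds shown here, two measured steps bear on it. The step of a 1.3-fold lower number from compound 1 to compound 2 (0.10 log units; within the scatter) exchanges the chloro-bearing pyridyl ether for the methyl-bearing one; the step of a 1.3-fold lower number from compound 2 to compound 3 (0.11 log units; within the scatter) exchanges the methyl-bearing pyridyl ether for the fluoro-bearing one. Compound 4 combines the methyl of compound 2 with the fluoro of compound 3. Every step recorded so far stays within the scatter, so no step beyond the scatter is expected here either; a number close to that of compound 2 seems the most likely outcome. Compound 4 is estimated at 5.5 10^-6 cm/s, within 3.5 10^-6 cm/s to 8.5 10^-6 cm/s, which corresponds to an expected step of a 1.2-fold higher number from compound 3 to compound 4 (0.07 log units; within the scatter).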

Compound 4, apparent permeability: 8.3 10^-6 cm/s
Estimate against measurement, compound 4: 1.5-fold (0.18 log units) below, within the range that was stated.
By their numbers in this assay, from the lowest: compounds 3, 2, 1 and 4 (each within the scatter of the next).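

Methyl in place of hydrogen on an aromatic carbon, ortho to a large group and two atoms from the ring nitrogen, can now be read directly in this assay: a 1.8-fold higher number from compound 3 to compound 4 (0.25 log units; within the scatter) shows that adding this group to the 5-fluoropyridin-2-yl ether does not produce a step beyond the scatter. The companion change, the entry of the fluoro group, gives a 1.4-fold higher number from compound 2 to compound 4 (0.14 log units; within the scatter), and exchanging 6-chloropyridin-2-yl for 5-fluoro-3-methylpyridin-2-yl gives a 1.1-fold higher number from compound 1 to compound 4 (0.04 log units; within the scatter), so neither step separates compound 4 from the compounds it is compared with. No supporting data are available to explain these small differences.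

On these data alone, the methyl change can be read only once, on the 5-fluoropyridin-2-yl ether, so whether it would stay within the scatter with a different substituent on the ring remains open. The compounds shown also leave open how an amine, a methoxy group or a longer alkyl chain at this aromatic carbon would read in this assay.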